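Swapping the ring on the far end of the core

The compounds below may be only part of what the source reports. "The series", "measured", "known", "first", "only" and "open" are said of these compounds alone.

The numbers below come from a functional assay on HEK293 cells for agonist activity at Bombesin receptor subtype-3 (Mus musculus), read by luminescence and calcium flux, with a stated time of 10 min; a higher number here means that more compound is needed for the effect, a lower number that less compound is needed.

Compound 1 `CCC(C)(C)Cc1c[nH]c(CCc2ccc(-c3cccc(N)n3)cc2)n1`: 3.9 nM
Compound 2 `CCC(C)(C)Cc1c[nH]c(CCc2ccc(-n3cccn3)cc2)n1`: 9 nM
Compound 3 `CCC(C)(C)Cc1c[nH]c(CCc2ccc(-c3ccns3)cc2)n1`: 3.1 nM

Compound 3 has the lowest number of the three, yet its gap to compound 1 is within the scatter; only compound 2 sits clearly higher, as a 2.9-fold lower number from compound 2 to compound 3 (0.46 log units; beyond the scatter) shows. Compound 4 `CCC(C)(C)Cc1c[nH]c(CCc2ccc(-c3cccc(C)n3)cc2)n1` differs from compound 3 in one place: 6-methylpyridin-2-yl in place of 1,2-thiazol-5-yl on an aromatic carbon. The step that bears most on this is a 1.3-fold lower number from compound 1 to compound 3 (0.10 log units; within the scatter), in which a pyridin-2-yl with a different substituent gave a number within the scatter of the thiazole. A pyridin-2-yl therefore appears roughly as good as the thiazole here, and no step beyond the scatter is expected. Compound 4 is estimated at 4 nM, between 1.5 nM and 11 nM, meaning an expected step of a 1.3-fold higher number from compound 3 to compound 4 (0.11 log units; within the scatter).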

Compound 4, half-maximal effective concentration: 19 nM
For compound 4 the middle estimate is 4.8-fold (0.68 log units) below the measured one; measured number outside the range, above it.
By their numbers in this assay, from the lowest: compounds 3 and 1 (each within the scatter of the next); then compound 2; then compound 4.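

Methyl in place of amino on the pyridin-2-yl ring clearly costs activity (a 4.9-fold higher number from compound 1 to compound 4 (0.69 log units; beyond the scatter)), so the ring alone does not set the number; the group it carries matters too. The 6-methylpyridin-2-yl group also needs more compound than either 1,2-thiazol-5-yl (a 6.1-fold higher number from compound 3 to compound 4 (0.79 log units; beyond the scatter)) or 1H-pyrazol-1-yl (a 2.1-fold higher number from compound 2 to compound 4 (0.32 log units; beyond the scatter)). Nothing measured here explains this loss.

As far as these compounds go, it remains open how a pyridin-2-yl ring with a methoxy group, or with no added group at all, would compare with the amino and methyl versions.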